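From compound 2 to compound 3: a fluoro step

The compounds below may be only part of what the source reports. "The series", "measured", "known", "first", "only" and "open" are said of these compounds alone.

- Compound 1 `O=C(CN1CCN(C(=O)c2ccccc2)CC1)N1CCN(CCCc2c[nH]c3ccccc23)CC1` gives > 200000 nM (a limit)
- Compound 2 `COc1ccc2[nH]cc(CCCN3CCN(C(=O)CN4CCN(C(=O)c5ccccc5)CC4)CC3)c2c1` gives > 200000 nM (a limit)

In an ADME assay on HEK293 cells (Homo sapiens) for cytotoxicity, read by MTT assay, with a stated time of 72 h (on this read-out higher numbers stand for weaker inhibition and lower numbers for stronger inhibition), compound 2 gives > 200000 nM as a limit of the assay and not a number. Compound 2 thus stands at the limit of > 200000 nM in this assay, at which 2 of the 2 values shown sit, and has no exact value of its own.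

The next compound is compound 3 `COc1ccc2[nH]cc(CCCN3CCN(C(=O)CN4CCN(C(=O)c5ccc(F)cc5)CC4)CC3)c2c1` and it differs from compound 2 in one place. The change is fluoro in place of hydrogen on an aromatic carbon and in words it is fluoro in place of hydrogen on an aromatic carbon, turning phenyl into 4-fluorophenyl.

Within the data shown here, only one measured step bears on this, and it is a different replacement: a step that the two limits leave unreadable from compound 1 to compound 2 with methoxy in place of hydrogen on an aromatic carbon. That step offers no size to carry over, so no step beyond the usual scatter is expected in this assay and no direction can be named. Compound 3 is expected to be reported as a limit again. The estimated step is a step that the limit leaves unreadable from compound 2 to compound 3 and it is expected to stay within the scatter. The estimate for compound 3 is 250000 nM with an expected range from 120000 nM to 500000 nM should a number be reported at all.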

Compound 3, half-maximal inhibitory concentration: > 200000 nM
Compound 3: only a limit was reported; the forecaster's own chance of this, stated with the estimate: 80%; the middle value does not contradict the limit.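

In this assay compound 3 gives > 200000 nM, a limit of the assay and not a number. Among these compounds, compound 2 also stands at a limit, so no step from compound 2 to compound 3 can be read. The compounds shown leave open what exact value each would have, and so whether fluoro in place of hydrogen makes any difference.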